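The compounds below may be only part of what the source reports. "The series", "measured", "known", "first", "only" and "open" are said of these compounds alone.

Compound 2 `Nc1ccc(S(=O)(=O)N2CCN(c3ncc(C(O)(C(F)(F)F)C(F)(F)F)cc3C#CC3CC3)CC2)cn1` is known in an ADME assay (liver) for metabolic stability, with Liver microsome (Homo sapiens) as the target, using microsomes and NADPH, with a stated time of 30 min, tested at 1 uM (on this read-out lower numbers stand for slow clearance and higher numbers for fast clearance), only through < 14 mL.min-1.g-1, which is a limit of the assay rather than a number. Compound 1 `COc1cc(C(O)(C(F)(F)F)C(F)(F)F)cnc1N1CCN(S(=O)(=O)c2ccc(N)nc2)CC1` likewise gives < 14 mL.min-1.g-1, again a limit. Compound 3 `COCC#Cc1cc(C(O)(C(F)(F)F)C(F)(F)F)cnc1N1CCN(S(=O)(=O)c2ccc(N)nc2)CC1` gives 15 mL.min-1.g-1. Two of the three values therefore stand at the same point, (the limit of < 14 mL.min-1.g-1 in this assay, at which 2 of the 3 values shown sit). Compound 4 `CC(C)(C)n1cc(-c2cc(C(O)(C(F)(F)F)C(F)(F)F)cnc2N2CCN(S(=O)(=O)c3ccc(N)nc3)CC2)cn1` differs from compound 2 in one place: 1-(tert-butyl)-1H-pyrazol-4-yl in place of 2-cyclopropylethynyl on an aromatic carbon. Among the compounds with values here, no measured step carries this exact change; the nearest is an at least 1.0-fold higher number from compound 2 to compound 3 (0.02 log units; that floor lies within the scatter), which lies within the scatter, while a step that the two limits leave unreadable from compound 1 to compound 2 cannot be read from the two limits. For compound 4 the step is therefore expected to be a number no lower from compound 2 to compound 4 (the limit leaves the size open), with no direction claimed beyond the scatter. Compound 4 is expected to give about 14 mL.min-1.g-1, between 7 mL.min-1.g-1 and 30 mL.min-1.g-1.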

Compound 4, intrinsic clearance in microsomes: 86 mL.min-1.g-1
Compound 4: the middle estimate sits 6.1-fold (0.79 log units) below what was measured; measured number outside the range, above it.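

At this position on the shared core, the earlier groups gave no readable step beyond the scatter, whereas 1-(tert-butyl)-1H-pyrazol-4-yl clearly does in this assay: there is an at least 6.1-fold higher number from compound 2 to compound 4 (0.78 log units; beyond the scatter), an at least 6.1-fold higher number from compound 1 to compound 4 (0.78 log units; beyond the scatter) and a 5.7-fold higher number from compound 3 to compound 4 (0.76 log units; beyond the scatter). The steps from compound 1 and compound 2 are floors only, and only the step from compound 3 has a full size: the limit of < 14 mL.min-1.g-1 in this assay, at which 2 of the 4 values shown sit. The compounds shown leave open whether the higher number follows the pyrazole ring itself or the tert-butyl group on it; a 1-methyl-1H-pyrazol-4-yl group at this position would separate the two.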